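The compounds below may be only part of what the source reports. "The series", "measured", "known", "first", "only" and "open" are said of these compounds alone.

Measured compounds:
compound 1 `Cc1c(Br)cc2nc3n(c2c1Br)[C@H]1OC[C@@H](OCc2ccccc2)[C@H]1OC3`; in an ADME assay on HEp-2 cells (Homo sapiens) for cytotoxicity, read by MTT assay, with a stated time of 60 h (a higher number here means that more compound is tolerated, a lower number that less compound is tolerated), compound 1 gives 115000 nM
compound 2 `Cc1ccc(S(=O)(=O)O[C@@H]2CO[C@H]3[C@@H]2OCc2nc4cc(Br)c(C)c(Br)c4n23)cc1`; in this assay compound 2 gives 88600 nM
compound 3 `Cc1ccc(S(=O)(=O)O[C@@H]2CO[C@H]3[C@@H]2OCc2nc4c(Br)c(C)c(Br)cc4n23)cc1`; in this assay compound 3 gives 8940 nM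

Compound 3 has the lowest number of the three in this assay; compound 2 stands nearest to it and compound 1 furthest, both beyond the scatter. The cores of compound 2 and compound 3 hold the same atoms joined differently; the difference between the two cores is not broken down here.

One change is seen once so far: benzyl in place of (4-methylphenyl)sulfonyl on an oxygen on a saturated carbon, which gave a 1.3-fold higher number from compound 2 to compound 1 (0.11 log units; within the scatter).

Compound 4 `Cc1c(Br)cc2c(nc3n2[C@H]2OC[C@@H](OCc4ccccc4)[C@H]2OC3)c1Br` is not yet measured in this assay. It carries the same kind of change from compound 3: benzyl in place of (4-methylphenyl)sulfonyl on an oxygen on a saturated carbon; the place is the same word for word as for compound 1 from compound 2. The expected step is a 1.2-fold higher number from compound 3 to compound 4 (0.09 log units; within the scatter), resting on compound 2 to compound 1 with a 1.3-fold higher number from compound 2 to compound 1 (0.11 log units; within the scatter). Compound 4 is estimated at 11000 nM, expected between 5000 nM and 25000 nM.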

Compound 4, half-maximal cytotoxic concentration: 25600 nM
For compound 4 the middle estimate is 2.3-fold (0.37 log units) below the measured one; measured number above the stated range.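

In this assay benzyl in place of (4-methylphenyl)sulfonyl on an oxygen on a saturated carbon gives a 2.9-fold higher number from compound 3 to compound 4 (0.46 log units; beyond the scatter) on the second core. Set beside the first step, the change carries over between the two cores with no gap that stands clear of the scatter: the same change on two cores in this assay, a 1.3-fold higher number (0.11 log units; within the scatter) from compound 2 to compound 1 and a 2.9-fold higher number (0.46 log units; beyond the scatter) from compound 3 to compound 4, 2.2-fold (0.34 log units) apart, within the scatter of two such steps
Two pairs on two closely related cores do not fix a size for this step, and they show nothing about how it would behave on any further core.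

As far as these compounds go, only benzyl and (4-methylphenyl)sulfonyl are seen on this oxygen, so an amine, a carboxylic acid or a longer alkyl chain in that place remains open. Also open, from the compounds shown here alone, is how the numbers would move with chlorine or hydrogen in place of either bromine on the core.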